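Methylation of the naphthol oxygen in the series

The source may hold more compounds than are shown below. What is called first, only, known or untested is meant among the compounds shown, and "the series" means these compounds.

Compound 1 `N#CC1=C(N)N(c2ccc(S(N)(=O)=O)cc2)C2=C(C(=O)CCC2)C1c1ccc(O)cc1` carries a 4-hydroxyphenyl group on a saturated ring carbon of the shared core. In a functional assay on Ehrlich cells (Mus musculus) for antiproliferative activity, read by trypan blue exclusion, with a stated time of 2 h (a lower number here means a stronger inhibitor, a higher number a weaker inhibitor), compound 1 gives 3 ug/mL. Compound 2 `N#CC1=C(N)N(c2ccc(S(N)(=O)=O)cc2)C2=C(C(=O)CCC2)C1c1c(O)ccc2ccccc12` bears 2-hydroxynaphthalen-1-yl in place of that group. In this assay compound 2 gives > 100 ug/mL, which is a limit of the assay and not a number. Within the data shown here, the one measured step, an at least 33-fold higher number from compound 1 to compound 2 (1.52 log units; beyond the scatter), is therefore known only as a lower bound, set by the limit of > 100 ug/mL in this assay, at which 1 of the 2 values shown sits. Compound 2 thus stands at the weak end of the pair, with no number to anchor it.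

Compound 3 `COc1ccc2ccccc2c1C1C(C#N)=C(N)N(c2ccc(S(N)(=O)=O)cc2)C2=C1C(=O)CCC2` follows from compound 2 by methyl in place of hydrogen on an oxygen on an aromatic ring. Among the measured compounds shown here, no measured step touches the hydroxy oxygen itself; the only step available, an at least 33-fold higher number from compound 1 to compound 2 (1.52 log units; beyond the scatter), exchanges the whole aryl group rather than its oxygen, so it bears on this change only loosely. For compound 3 the step that the limit leaves unreadable from compound 2 to compound 3 in this assay is expected to be none beyond the scatter, with a limit more likely than a number. Compound 3 is thus estimated at 150 ug/mL, within 40 ug/mL to 500 ug/mL.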

Compound 3, half-maximal inhibitory concentration: 12.5 ug/mL
Compound 3: the middle estimate sits 12-fold (1.08 log units) above what was measured; measured number outside the range, below it.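

Methyl in place of hydrogen on the oxygen on the aromatic ring is the first change in the series at this oxygen, and in this assay it brings the 2-hydroxynaphthalen-1-yl compound back to a readable value: an at least 8.0-fold lower number from compound 2 to compound 3 (0.90 log units; beyond the scatter). Compound 2 stands at a limit of the assay and not at a number, so this step is only a lower bound: the limit of > 100 ug/mL in this assay, at which 1 of the 3 values shown sits.

The weak reading of compound 2 therefore does not extend to every aryl group built on naphthalene, although the 2-methoxynaphthalen-1-yl group still falls short of the 4-hydroxyphenyl group: a 4.2-fold higher number from compound 1 to compound 3 (0.62 log units; beyond the scatter).

The compounds shown leave open whether the gain belongs to the methyl group itself or simply to the loss of the hydrogen on that oxygen, a question that an ethyl group or an acetyl group on the same oxygen would help to separate. Also open, going by these compounds, is whether methyl on the oxygen of the 4-hydroxyphenyl group of compound 1, which would give a 4-methoxyphenyl group, moves the number in the same direction.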